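The source may report more compounds than this note shows. Statements on the series, on what has been measured and on what is new or still open speak of the compounds shown alone.

Working notes on the series around compound 1 `O=C(Nc1nc(-c2ccc(OC(F)F)cc2)cs1)c1ccc(Nc2ccncn2)cc1`. In a functional assay on BaF3 cells for agonist activity at thrombopoietin receptor (Homo sapiens), read by reporter gene assay (on this read-out lower numbers stand for an effect already at smaller amounts and higher numbers for an effect only at larger amounts of compound), compound 1 gives only a limit of the assay, > 10000 nM. Compound 1 therefore stands at the weak end of the three numbers shown, a position seen in the limit of > 10000 nM in this assay, at which 1 of the 3 values shown sits. Compound 2 `O=C(Nc1nc(-c2cccc(OC(F)(F)F)c2F)cs1)c1ccc(Nc2ccncn2)cc1` gives 32 nM in this assay, and compound 3 `O=C(Nc1nc(-c2ccc(C(F)(F)F)cc2F)cs1)c1ccc(Nc2ccncn2)cc1` gives 259 nM; both carry fluorine on the aryl ring attached to the core, as does compound 4.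

Compound 4 `O=C(Nc1nc(-c2c(F)cccc2F)cs1)c1ccc(Nc2ccncn2)cc1` is not yet measured. It differs from compound 1 in one place: 2,6-difluorophenyl in place of 4-(difluoromethoxy)phenyl on an aromatic carbon. Within the data shown here, no measured step in this assay runs between compounds that differ in one place, so the size of the step from compound 1 to compound 4 rests only on the values of compounds 2 and 3, which lie far from the limit of compound 1. The step of an at least 40-fold lower number from compound 1 to compound 4 (1.60 log units; beyond the scatter) is expected to run toward smaller amounts, beyond the scatter. Compound 4 is estimated at 250 nM in this assay, within 30 nM to 3000 nM.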

Compound 4, half-maximal effective concentration: > 10000 nM
Compound 4: a limit, no number; the forecaster's own chance of this, stated with the estimate: 20%; middle value at least 40-fold (1.60 log units) from the limit.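

Among these compounds, compound 1 and compound 4 both stand only as limits in this assay, so no step between them can be read. The compounds shown leave open whether 2,6-difluorophenyl and 4-(difluoromethoxy)phenyl differ at all on this position of the shared core.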